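The source may hold more compounds than are shown below. What is called first, only, known or untested is meant among the compounds shown, and "the series" means these compounds.

Compound 1 `CC1CN(c2c(F)c(N)c3c(=O)c(C(=O)O)cn(C4CC4)c3c2F)CC(C)N1CN1C(=O)C(=O)c2ccccc21`: in a functional assay on HepG2 cells (Homo sapiens) for antiproliferative activity, read by MTT assay, with a stated time of 48 h (on this read-out lower numbers stand for stronger inhibition and higher numbers for weaker inhibition), compound 1 gives >= 18.3 ug/mL, which is a limit of the assay.
Compound 2 `CC1CN(c2c(F)c(N)c3c(=O)c(C(=O)O)cn(C4CC4)c3c2F)CC(C)N1CN1C(=O)/C(=N\c2ccc(S(=O)(=O)Nc3ncccn3)cc2)c2ccccc21`: in this assay compound 2 gives >= 18.3 ug/mL, again a limit.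
Compound 3 `COc1ncnc(NS(=O)(=O)c2ccc(/N=C3\C(=O)N(CN4C(C)CN(c5c(F)c(N)c6c(=O)c(C(=O)O)cn(C7CC7)c6c5F)CC4C)c4ccccc43)cc2)c1OC`: in this assay compound 3 gives 18.3 ug/mL.

Among the compounds with values here, compound 3 thus holds the only number in the set; the two other values sit at the limit of >= 18.3 ug/mL in this assay, at which 2 of the 3 values shown sit. Within the data shown here, the one measured step, a number no higher from compound 2 to compound 3 (the limit leaves the size open), has no readable size. Compound 4 `Cc1cc(C)nc(NS(=O)(=O)c2ccc(/N=C3\C(=O)N(CN4C(C)CN(c5c(F)c(N)c6c(=O)c(C(=O)O)cn(C7CC7)c6c5F)CC4C)c4ccccc43)cc2)n1` differs from compound 3 by 4,6-dimethylpyrimidin-2-yl in place of 5,6-dimethoxypyrimidin-4-yl on a sulfonamide nitrogen. Among the measured compounds shown here, no measured step other than that one bears on this change, so no shift beyond the scatter in this assay is expected in either direction. The step from compound 3 to compound 4 is expected to be a 1.1-fold higher number from compound 3 to compound 4 (0.04 log units; within the scatter). For compound 4 the estimate in this assay is 20 ug/mL, between 9 ug/mL and 60 ug/mL, with a fair chance that only a limit is reported.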

Compound 4, half-maximal inhibitory concentration: >= 18.3 ug/mL
Compound 4 ended at the assay's limit; the forecaster's own chance of this, stated with the estimate: 50%; the middle value lies beyond the limit too.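

In this assay putting 4,6-dimethylpyrimidin-2-yl in place of 5,6-dimethoxypyrimidin-4-yl on a sulfonamide nitrogen gives a number no lower from compound 3 to compound 4 (the limit leaves the size open) and so no new number. Compound 4 joins compound 1 and compound 2 in carrying only a limit, and the sizes of the steps among these compounds cannot be read. The values gather at one end of the scale: the limit of >= 18.3 ug/mL in this assay, at which 3 of the 4 values shown sit.

On these data alone, whether an amine or a carboxylic acid on the pyrimidine ring, or a plain phenyl in its place, would bring a clearly lower number stays open. Any ranking of compound 2 and compound 4 also stays open.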